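This account rests on a few compounds, and the source may have more. Where it says the series, first, only, none or still open, it means among the compounds named here.

In a physicochemical assay for solubility, at pH 2 (on this read-out lower numbers stand for lower solubility and higher numbers for higher solubility), compound 1 `CS(=O)(=O)c1cncc(-c2cnc3ccc(-c4cccc(S(=O)(=O)C5CC5)c4)nn23)c1` gives 18000 nM, and compound 2 `NC(=O)c1ccc(-c2cnc3ccc(-c4cccc(S(=O)(=O)C5CC5)c4)nn23)cc1` gives 6300 nM. Exchanging one group for another between these two produces a 2.9-fold lower number from compound 1 to compound 2 (0.46 log units; beyond the scatter). Compound 3 `CS(=O)(=O)c1cccc(-c2ccc3ncc(-c4ccc(S(C)(=O)=O)nc4)n3n2)c1` reads < 5000 nM, which is a limit of the assay and not a number. That reading for compound 3 is the limit of < 5000 nM in this assay, at which 1 of the 3 values shown sits, so its true position is not pinned down.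

Compound 4 `CS(=O)(=O)c1ccc(-c2cnc3ccc(-c4cccc(S(=O)(=O)C5CC5)c4)nn23)cn1` has not yet been measured. Going from compound 3 to compound 4 is a small edit, cyclopropyl in place of methyl on a sulfonyl sulfur.

Among the compounds with values here, no measured step tests this exchange directly. The step from compound 1 to compound 2 concerns a different group, so its size is only a rough guide to how far a single exchange can move this assay in this small set. Compound 1 and compound 2 both carry cyclopropylsulfonyl, as compound 4 does, and compound 2 at 6300 nM gives a real number. A real number for compound 4 therefore remains possible.

With no direction supported by the data, the expected change is none beyond the scatter, and the estimated step is a step that the limit leaves unreadable from compound 3 to compound 4. Compound 4 is expected to read about 4000 nM, within an estimated range of 1200 nM to 12000 nM.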

Compound 4, solubility: < 5000 nM
Compound 4: a limit, no number; the forecaster's own chance of this, stated with the estimate: 55%; the middle value lies beyond the limit too.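

In this assay compound 4 gives < 5000 nM, which is a limit of the assay and not a number. The step from methylsulfonyl to cyclopropylsulfonyl cannot be read, because both of its compounds rest at the same limit: the limit of < 5000 nM in this assay, at which 2 of the 4 values shown sit. With cyclopropylsulfonyl held in place, 6-(methylsulfonyl)pyridin-3-yl in place of 5-(methylsulfonyl)pyridin-3-yl on an aromatic carbon gives an at least 3.6-fold lower number from compound 1 to compound 4 (0.55 log units; beyond the scatter), so carrying cyclopropylsulfonyl does not by itself keep a compound clear of the limit, while 6-(methylsulfonyl)pyridin-3-yl in place of 4-carbamoylphenyl gives an at least 1.2-fold lower number from compound 2 to compound 4 (0.10 log units; that floor lies within the scatter), a floor too small to set those two compounds in any order.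

Where compound 3 and compound 4 truly lie beyond the limit remains open, and with it whether cyclopropyl and methyl on the sulfonyl sulfur differ at all in this read-out. Also open, from the compounds shown here alone, is how the read-out would respond to an amine or a carboxylic acid in place of the methylsulfonyl group on the aromatic ring of compound 4.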